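The source may report more compounds than this note shows. Statements on the series, on what has been measured and on what is new or still open speak of the compounds shown alone.

Compound 1 `Cc1ncccc1Oc1ccc(-c2ccn(CCC(C)C)c(=O)c2C#N)cc1` reaches 256% in a functional assay on CHO cells for positive allosteric modulation of metabotropic glutamate receptor 2 (Homo sapiens), read by scintillation counting and GTPgammaS binding, with a stated time of 30 min; on this read-out higher numbers stand for larger maximal responses and lower numbers for smaller maximal responses. Compound 2 `Cc1ccc(Oc2ccc(-c3ccn(CCC(C)C)c(=O)c3C#N)cc2)c(C)n1` carries the change methyl in place of hydrogen on an aromatic carbon and gives 246% in this assay, so that the step of a number 10 percentage points lower from compound 1 to compound 2 (within the scatter) stays within the scatter. Compound 3 `CCCCn1ccc(-c2ccc(Oc3cccnc3C)c(Cl)c2)c(C#N)c1=O` has a core whose difference from that of compound 1 is not broken down here; in this assay compound 3 gives 236%, the lowest of the three numbers. Among the compounds with values here, compound 4 `CCCCn1ccc(-c2ccc(Oc3ccc(C)nc3C)c(Cl)c2)c(C#N)c1=O` has not yet been measured and differs from compound 3 by methyl in place of hydrogen on an aromatic carbon, the same change as the one between compound 1 and compound 2, at the same place. Resting on the earlier step of a number 10 percentage points lower from compound 1 to compound 2 (within the scatter), the step expected here is a number 10 percentage points lower from compound 3 to compound 4 (within the scatter). Compound 4 is therefore estimated at 226% in this assay, expected to lie between 200% and 255%.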

Compound 4, largest response reached (Emax), in percent of the reference or control that the assay uses: 231%
The estimate for compound 4 lay 5 percentage points below the measured number, within the range that was stated.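

In this assay, the methyl that turns 2-methylpyridin-3-yl into 2,6-dimethylpyridin-3-yl gives a number 5 percentage points lower from compound 3 to compound 4 (within the scatter). The change therefore carries over between these two cores with steps that agree: the same change on two cores in this assay, a number 10 percentage points lower (within the scatter) from compound 1 to compound 2 and a number 5 percentage points lower (within the scatter) from compound 3 to compound 4, 5 percentage points apart, within the scatter of two such steps. This shows only that the maximal response stayed within the scatter on both cores; with both steps inside the scatter, it does not show that the methyl has any effect of its own, nor that the same would hold on a third core.

The compounds shown leave open what a different group at that place, such as an ethyl, a methoxy or an amine, would do to the response. They also leave open how the response would change with a longer chain on the ring nitrogen of the shared core.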